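Replacing the chloro-methyl anilide in a thiazolyl-quinazoline series

The source may report more compounds than this note shows. Statements on the series, on what has been measured and on what is new or still open speak of the compounds shown alone.

Of the compounds shown here, three of one shared core have been measured. Compound 1 `COc1cc2c(Nc3nc4ccc(C(=O)Nc5c(C)cccc5Cl)cc4s3)ncnc2cc1OCCCN1CCC(C)CC1` gives 8300 nM in a functional assay on K562 cells (Homo sapiens) for cytotoxicity, read by WST assay, with a stated time of 72 h; a higher number here means a weaker inhibitor, a lower number a stronger inhibitor. Compound 2 `CCN(CC)CCCOc1cc2ncnc(Nc3nc4ccc(C(=O)Nc5c(C)cccc5Cl)cc4s3)c2cc1OC` gives 9600 nM in this assay, and compound 3 `COc1cc2c(Nc3nc4ccc(C(=O)Nc5c(C)cccc5Cl)cc4s3)ncnc2cc1OCCCN1CCCC1` gives 13300 nM. Compound 2 stands second highest of the three numbers, with compound 1 nearest and compound 3 furthest; every step among them lies within the scatter: a 1.2-fold higher number from compound 1 to compound 2 (0.06 log units; within the scatter), a 1.6-fold higher number from compound 1 to compound 3 (0.20 log units; within the scatter) and a 1.4-fold higher number from compound 2 to compound 3 (0.14 log units; within the scatter). Those three steps all vary the amine on the saturated chain, three bonds along the chain from an oxygen on an aromatic ring, and none of them moves the number beyond the scatter.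

Compound 4 `CCN(CC)CCCOc1cc2ncnc(Nc3nc4ccc(C(=O)Nc5c(C)cc(C)cc5C)cc4s3)c2cc1OC` differs from compound 2 elsewhere: 2,4,6-trimethylphenyl in place of 2-chloro-6-methylphenyl on an amide-type nitrogen. Among the compounds with values here, no measured step touches this amide-type nitrogen, so nothing among the measured compounds bears directly on the change. Within the data shown here, the only guidance is that the three measured numbers sit close together in this assay, and on that basis the step from compound 2 to compound 4 is expected to be small, with no direction to be read from the data, as a 1.1-fold higher number from compound 2 to compound 4 (0.06 log units; within the scatter). Compound 4 is therefore estimated at 11000 nM, within a range of 4000 nM to 30000 nM, the width reflecting that the changed part has not been probed.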

Compound 4, half-maximal inhibitory concentration: 6800 nM
Compound 4: the middle estimate sits 1.6-fold (0.21 log units) above what was measured; the measured number falls inside the stated range.
By their numbers in this assay, from the lowest: compounds 4, 1, 2 and 3 (each within the scatter of the next).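

Within the data shown here, this is the first step that touches the aryl group on the amide-type nitrogen: in this assay, 2,4,6-trimethylphenyl in place of 2-chloro-6-methylphenyl gives a 1.4-fold lower number from compound 2 to compound 4 (0.15 log units; within the scatter), which lies within the scatter. The change swaps an aryl group carrying chlorine for one made of carbon only, and with the diethylamino chain kept in place, the number stays within the scatter, so for this pair the chlorine is not needed to hold the number at this level. Like the amine on the saturated chain, this part of the molecule has now been changed without moving the number beyond the scatter, although this rests on a single pair, and nothing available accounts for the outcome.

The compounds shown leave open whether a plain phenyl, a pyridine ring or an aryl group bearing a carboxylic acid would be accommodated on the same nitrogen as readily. They also leave open whether 2,4,6-trimethylphenyl behaves the same way when paired with the 4-methylpiperidin-1-yl or pyrrolidin-1-yl chain.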